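Chalcone-pyrazole series: dimethoxyphenyl replacing aminophenyl

A few compounds are considered here, and "the series" means these few. Any claim that something is new, unique, unknown or untested is made for them only; others in the source may bear on it.

Compound 1 `COc1cc(-c2cc(/C=C/C(=O)c3ccc(N)cc3)[nH]n2)cc(OC)c1OC` gives 3240 nM in a functional assay on RXF 393 cells (Homo sapiens) for inhibition, read by sulforhodamine B assay, with a stated time of 48 h; a higher number here means a weaker inhibitor of growth, a lower number a stronger inhibitor of growth. Compound 2 `COc1ccc(-c2cc(/C=C/C(=O)c3ccc(OC)c(OC)c3)[nH]n2)cc1` gives 2940 nM and compound 3 `COc1ccc(-c2cc(/C=C/C(=O)c3ccc(N)cc3)[nH]n2)cc1` gives 4190 nM. On these three numbers compound 1 sits second highest, with compound 2 nearest and compound 3 furthest, and both gaps lie within the scatter, so no order among the three can be read.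

Compound 4 `COc1ccc(C(=O)/C=C/c2cc(-c3cc(OC)c(OC)c(OC)c3)n[nH]2)cc1OC` is not yet measured. It differs from compound 1 by 3,4-dimethoxyphenyl in place of 4-aminophenyl on a carbonyl carbon. Among the measured compounds shown here, no step between measured compounds is available for this change. The numbers of compound 3 and compound 2 differ in the same sense, within the scatter. A small lowering is expected, a 1.3-fold lower number from compound 1 to compound 4 (0.11 log units; within the scatter). For compound 4 the expected value is 2500 nM, with a range from 1000 nM to 6000 nM.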

Compound 4, concentration for total growth inhibition: 2660 nM
Compound 4: middle estimate off by 1.1-fold (0.03 log units), on the low side; low and high end bracket the measured number.
By their numbers in this assay, from the lowest: compounds 4, 2, 1 and 3 (each within the scatter of the next).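

In this assay, among the compounds shown here, 3,4-dimethoxyphenyl in place of 4-aminophenyl on a carbonyl carbon gives a 1.2-fold lower number from compound 1 to compound 4 (0.09 log units; within the scatter), the first step in this set that isolates a change at this position. The entering group is larger and has no hydrogen-bond donor, yet the step stays within the scatter. Nothing measured here bears on why this step is so small.

On these data alone, whether a carboxylic acid or a plain phenyl on that carbonyl carbon would give a step beyond the scatter remains open.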